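The source may report more compounds than this note shows. Statements on the series, on what has been measured and on what is new or still open speak of the compounds shown alone.

For the measured compounds named here, compound 3 `COc1cccc(OC)c1OCCNCCOc1ccccc1OCc1ccc(Cl)cc1` holds the lowest of the three numbers so far in a functional assay on PC-3 cells (Homo sapiens) for cytotoxicity, read by sulforhodamine B assay (a lower number here means a stronger inhibitor of growth, a higher number a weaker inhibitor of growth), giving 14500 nM. Compound 2 `COc1cccc(OC)c1OCCNCCOc1ccccc1OCc1ccccc1Cl` gives 17800 nM, and the step of a 1.2-fold lower number from compound 2 to compound 3 (0.09 log units; within the scatter) stays within the scatter. Compound 1 `COc1cccc(OC)c1OCCNCCOc1ccccc1OCc1ccccc1` gives 76900 nM, and the steps of a 4.3-fold lower number from compound 1 to compound 2 (0.64 log units; beyond the scatter) and a 5.3-fold lower number from compound 1 to compound 3 (0.72 log units; beyond the scatter) both add a chloro and both lower the number modestly. Compound 4 `COc1cccc(OC)c1OCCNCCOc1ccccc1OCc1ccccc1C` carries 2-methylphenyl in place of 4-chlorophenyl on a saturated chain carbon bound to an oxygen on an aromatic ring. Going by the values given here, no measured step swaps chloro for methyl, so only the chloro steps bear on it: removing the chloro points back toward the number of compound 1, while the methyl is untested. For compound 4 the step expected is a 1.9-fold higher number from compound 3 to compound 4 (0.29 log units; within the scatter), a modest rise. Compound 4 is therefore estimated at 28000 nM, within 10000 nM to 75000 nM.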

Compound 4, concentration for total growth inhibition: 33900 nM
Estimate against measurement, compound 4: 1.2-fold (0.08 log units) below; low and high end bracket the measured number.
By their numbers in this assay, from the lowest: compounds 3, 2 and 4 (each within the scatter of the next, the first and the last beyond it); then compound 1.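

Methyl in place of hydrogen also lowers the number in this assay with a 2.3-fold lower number from compound 1 to compound 4 (0.36 log units; beyond the scatter), so chloro is not the only group here that does so. Methyl in place of chloro gives a 1.9-fold higher number from compound 2 to compound 4 (0.28 log units; within the scatter), which leaves the two groups apart by no more than the scatter, whereas 2-methylphenyl in place of 4-chlorophenyl gives a 2.3-fold higher number from compound 3 to compound 4 (0.37 log units; beyond the scatter), a step that changes both the group and where it sits. No measurement shown here accounts for these steps. Still open, going by these compounds, is how an amine or a carboxylic acid on this aromatic ring would compare with methyl and chloro.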